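The compounds below may be only part of what the source reports. "The series", "measured", "known", "first", "only" and "open" are said of these compounds alone.

Compound 1, `CC(c1ccccc1)c1cc(O)nc(SC2CCCC2)n1`, and compound 2, `CC(c1ccccc1)c1cc(O)nc(SC2CCCCC2)n1`, share a core and differ in only one place: cyclohexyl in place of cyclopentyl on a sulfur. In a functional assay on MT4 cells (Homo sapiens) for cytotoxicity (on this read-out lower numbers stand for higher toxicity in this test and higher numbers for lower toxicity in this test), compound 1 gives 159000 nM, and in this assay compound 2 gives 149000 nM. The measured step of a 1.1-fold lower number from compound 1 to compound 2 (0.03 log units; within the scatter) is thus a very small one. Compound 3, `CC(c1cc(O)nc(SC2CCCC2)n1)c1cccc2ccccc12`, carries a different core; how its core differs from that of compound 1 is not broken down here. In this assay compound 3 gives 93000 nM, a number that lies within the scatter of those of compound 1 and compound 2, so the three cannot be told apart on this read-out.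

Compound 4, `CC(c1cc(O)nc(SC2CCCCC2)n1)c1cccc2ccccc12`, has not yet been measured. It stands to compound 3 as compound 2 stands to compound 1: cyclohexyl in place of cyclopentyl on a sulfur. The place is described in the same words for both pairs, a sulfur whose other neighbours are an aromatic carbon, so this is the same change carried onto a second core. For the measured compounds named here, the only guide is the one measured instance of it, which barely moved the number. For compound 4 the expected step is a 1.1-fold lower number from compound 3 to compound 4 (0.04 log units; within the scatter), which rests on compound 3 with its 93000 nM and on the earlier step of a 1.1-fold lower number from compound 1 to compound 2 (0.03 log units; within the scatter). The expected value for compound 4 in this assay is therefore 85000 nM, with a likely span from 45000 nM to 170000 nM, kept wide as the change has been seen only once, in a 1.1-fold lower number from compound 1 to compound 2 (0.03 log units; within the scatter).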

Compound 4, half-maximal cytotoxic concentration: 45000 nM
Beside the measured number, compound 4's estimate is 1.9-fold (0.28 log units) above it, and the stated range covers the measured number.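

On the core of compound 3, putting cyclohexyl in place of cyclopentyl on a sulfur gives a 2.1-fold lower number from compound 3 to compound 4 (0.32 log units; beyond the scatter) in this assay, a modest step that only just clears the usual noise of this kind of test. Set beside the same change on the core of compound 1, this step cannot be told apart from the earlier one, so the change behaves alike on both cores as far as this test can show: the same change on two cores in this assay, a 1.1-fold lower number (0.03 log units; within the scatter) from compound 1 to compound 2 and a 2.1-fold lower number (0.32 log units; beyond the scatter) from compound 3 to compound 4, 1.9-fold (0.29 log units) apart, within the scatter of two such steps. This agrees with the change carrying over from one core to the other, but two pairs are too few to set a rule, and they show neither that the step is truly larger on the core of compound 3 nor why the numbers fall as they do.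

From the compounds shown here alone, both pairs swap one carbon-only ring for another on the same sulfur, so it remains open what an open chain such as butyl, or a group carrying an amine or a carboxylic acid, would do in that place. Also open, going by these compounds, is whether the same change would act alike on a third core, or in any test other than this one for harm to cells.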